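Swapping chloro for cyano on a thiocarbamate benzamide

The source may report more compounds than this note shows. Statements on the series, on what has been measured and on what is new or still open speak of the compounds shown alone.

Of the compounds shown here, two carrying the same benzamide core have been measured. Compound 1 `Nc1ccccc1NC(=O)c1ccc(CSC(=S)N2CCN(c3ccc(Cl)cc3)CC2)cc1` bears a 4-chlorophenyl on its piperazine, while compound 2 `CC1CCCCN1C(=S)SCc1ccc(C(=O)Nc2ccccc2N)cc1` carries a simple methylpiperidine in place of that arylpiperazine. In a functional assay on A-375 cells (Homo sapiens) for antiproliferative activity, read by CCK-8 assay, with a stated time of 72 h, tested at 8 uM (on this read-out higher numbers stand for a stronger effect at the one concentration tested and lower numbers for a weaker effect), compound 1 gives 29%, the lower of the two numbers; compound 2 gives 85.2%, a gap that lies beyond the usual scatter of this read-out. The two structures differ in more than one place, so nothing can be said about which part of that difference carries the gap.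

Among the measured compounds shown here, compound 3 `N#Cc1ccc(N2CCN(C(=S)SCc3ccc(C(=O)Nc4ccccc4N)cc3)CC2)cc1` keeps the arylpiperazine of compound 1 and changes only one group: cyano in place of chloro on an aromatic carbon. No comparable single change has been measured here, so the expectation for this step rests on compound 1 alone. The author expects the step from compound 1 to compound 3 in this assay to be small, a number 6 percentage points higher from compound 1 to compound 3 (within the scatter), most likely not clearly beyond the scatter in either direction. Compound 3 is therefore estimated at 35% in this assay, with a range from 15% to 60%.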

Compound 3, a percentage reported as inhibition, at one concentration (the size of the read-out at that concentration, not a potency): 62.9%
The estimate for compound 3 lay 27.9 percentage points below the measured number; measured number above the stated range.
By their numbers in this assay, from the lowest: compound 1; then compound 3; then compound 2.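

In this assay, cyano in place of chloro on an aromatic carbon, para to a large group, gives a number 33.9 percentage points higher from compound 1 to compound 3 (beyond the scatter) while the rest of the molecule stays the same. This position on the six-membered aromatic ring is therefore sensitive in this read-out, and the arylpiperazine alone does not hold the effect at the level of compound 1 at 29% in this test. Among the compounds shown here, compound 1 and compound 2 differ in more than one place, so this is the first gap here that can be tied to a single change, although no available measurement bears on why it occurs.

What an amine, a methoxy group or a carboxylic acid would give at this place remains open, so the compounds shown do not tell whether the nitrile is unusual or whether chloro is the poor choice here. Also open, as far as these compounds go, is which part of the structure separates compound 3 at 62.9% from compound 2 at 85.2% in this test, since those two differ in more than one place.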